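From pyridin-2-yl to phenyl on the ring amine

The compounds below may be only part of what the source reports. "The series", "measured", "known", "first", "only" and "open" are said of these compounds alone.

Three related compounds have so far been tested in a functional assay on A-375 cells (Homo sapiens) for inhibition, read by MTT assay, with a stated time of 48 h; on this read-out lower numbers stand for stronger inhibition and higher numbers for weaker inhibition. Compound 1 `COc1ccccc1OCCNCC(O)COc1cccc2ccccc12` gives 18900 nM, and compound 2 `COc1ccccc1OCCNCC(O)COc1ccc(-c2ccccc2)cc1` gives 8370 nM. Compound 3 `OC(COc1ccc(-c2ccccc2)cc1)CN1CCN(c2ccccn2)CC1` gives 28200 nM. Among the compounds with values here, this value lies within the usual scatter of the one for compound 1, so those two cannot be told apart. Compound 3 does show weaker inhibition than compound 2, by a margin beyond the scatter.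

The next compound, compound 4 `OC(COc1ccc(-c2ccccc2)cc1)CN1CCN(c2ccccc2)CC1`, keeps everything in compound 3 except one group: phenyl in place of pyridin-2-yl on an amine nitrogen in a ring. Within the data shown here, no pair of tested compounds differs in just one place, so the data offer no direct measure of what such a swap does. The group that leaves and the group that enters are both six-membered aromatic rings, so starting from compound 3 at 28200 nM, no change beyond the scatter is expected in this assay. The step expected here, a 1.3-fold lower number from compound 3 to compound 4 (0.11 log units; within the scatter), stays within the scatter. For compound 4 the estimated value is 22000 nM, with an expected range from 10000 nM to 48000 nM.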

Compound 4, half-maximal inhibitory concentration: 14300 nM
The estimate for compound 4 lay 1.5-fold (0.19 log units) above the measured number; the range from low to high includes it.
By their numbers in this assay, from the lowest: compounds 2, 4, 1 and 3 (each within the scatter of the next, the first and the last beyond it).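

Within the data shown here, this is the first pair of compounds that differ in one place, so it gives the first direct reading of a change on an amine nitrogen in a ring. In this assay, the step of a 2.0-fold lower number from compound 3 to compound 4 (0.29 log units; within the scatter) lies within the scatter, so compound 3 and compound 4 cannot be told apart, even though phenyl, made of carbon only, lacks the ring nitrogen and the hydrogen-bond acceptor counted on pyridin-2-yl. At this position and in this assay, that difference between two six-membered aromatic rings therefore produces no change that can be distinguished from repeat-measurement noise, and no measurement here offers any explanation at the level of the groups themselves.

This single pair cannot show whether the same swap would also leave the number unresolved on a different core, such as that of compound 1. It also leaves open whether a group of another kind on this amine nitrogen, such as benzyl, methyl or an acetyl group, would move the number beyond the scatter.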